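The source may hold more compounds than are shown below. What is called first, only, known or untested is meant among the compounds shown, and "the series" means these compounds.

Measured compounds in an assay for binding affinity to Indoleamine 2,3-dioxygenase 1 variant C129Y (Homo sapiens), read by spectrophotometry, with a stated time of 30 min; a lower number here means tighter binding, a higher number weaker binding:
compound 1 `Cc1cc(C(O)Cc2ccccc2)c2cn[nH]c2c1`, giving 27000 nM
compound 2 `OC(Cc1ccccc1)c1cc(Br)cc2[nH]ncc12`, giving 2200 nM
compound 3 `CCc1cc(C(O)Cc2ccccc2)c2cn[nH]c2c1`, giving 44000 nM

Among these three, compound 1 holds the second highest number in this assay. The nearest step is a 1.6-fold higher number from compound 1 to compound 3 (0.21 log units; within the scatter); the furthest is a 12-fold lower number from compound 1 to compound 2 (1.09 log units; beyond the scatter).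

Compound 4 `OC(Cc1ccccc1)c1cc(C2CC2)cc2[nH]ncc12` differs from compound 1 by cyclopropyl in place of methyl on an aromatic carbon. For the measured compounds named here, two measured steps bear on this. The change of methyl to ethyl, a carbon group of similar kind, was a 1.6-fold higher number from compound 1 to compound 3 (0.21 log units; within the scatter). The change of methyl to bromo was a 12-fold lower number from compound 1 to compound 2 (1.09 log units; beyond the scatter), but that step exchanged carbon for a halogen and is not the same kind of change. The carbon-for-carbon precedent is the closer one, so in this assay no step beyond the scatter is expected. The expected step is a 1.1-fold higher number from compound 1 to compound 4 (0.05 log units; within the scatter). Compound 4 is therefore estimated at 30000 nM, within 10000 nM to 90000 nM.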

Compound 4, dissociation constant: 28000 nM
Compound 4: middle estimate off by 1.1-fold (0.03 log units), on the high side; low and high end bracket the measured number.
By their numbers in this assay, from the lowest: compound 2; then compounds 1, 4 and 3 (each within the scatter of the next).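

In this assay, enlarging the methyl to a cyclopropyl at this aromatic carbon, adding a three-membered ring, leaves the number within the scatter: a 1.0-fold higher number from compound 1 to compound 4 (0.02 log units; within the scatter). The comparison with ethyl is also within the scatter, at a 1.6-fold lower number from compound 3 to compound 4 (0.20 log units; within the scatter), so the three carbon groups are not separated, while bromo stays apart, with a 13-fold higher number from compound 2 to compound 4 (1.10 log units; beyond the scatter). Nothing available accounts for the gap between bromo and these carbon groups.

As far as these compounds go, it remains open whether chloro or iodo would track bromo. An amine or a methoxy group at this carbon is also untested in the compounds shown here.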